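The source may report more compounds than this note shows. Statements on the series, on what has been measured and on what is new or still open speak of the compounds shown alone.

Measured compounds:
compound 1, `NC1=NC2(CCSCC2)N(OCCCOc2ccc(Br)cc2)C(N)=N1`, 6.46 nM
compound 2, `NC1=NC2(CCOCC2)N(OCCCOc2cccc(Cl)c2Cl)C(N)=N1`, "not determined" (no result reported)
compound 3, `NC1=NC2(CCSCC2)N(OCCCOc2ccccc2Br)C(N)=N1`, "not determined" (no result reported)

In an assay on isolated protein for inhibition of Dihydrofolate reductase (Homo sapiens), read by spectrophotometry, using NADPH, with stated times of 5 s and 6 min (on this read-out higher numbers stand for weaker inhibition and lower numbers for stronger inhibition), compound 1 gives 6.46 nM. In this assay, going by the values given here, compound 2 gives "not determined" (no result reported), and compound 3 gives "not determined" (no result reported), so both came back without a single number and compound 2 stands nowhere on the scale: there is no value for it, and the one other compound without a number, compound 3, gives it no company on the scale either. Among the compounds with values here, the only figure in the set is the one for compound 1.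

Compound 4, `NC1=NC2(CCOCC2)N(OCCCOc2ccc(Br)cc2)C(N)=N1`, is to be measured in this assay. It differs from compound 2 in one place: 4-bromophenyl in place of 2,3-dichlorophenyl on an oxygen on a saturated carbon. Compound 2 has no number. Within the data shown here, no step of any size can be stated from compound 2 to compound 4 in this assay, neither upward nor downward, and nothing can be said about whether it lies beyond the scatter. What the data do show is that compound 1, which carries the same 4-bromophenyl on an oxygen on a saturated carbon, gives 6.46 nM. On that basis alone compound 4 is expected to give about 9 nM in this assay, with a likely range from 2.5 nM to 35 nM.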

Compound 4, half-maximal inhibitory concentration: 32.5 nM
Compound 4: the middle estimate sits 3.6-fold (0.56 log units) below what was measured; the range from low to high includes it.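

In this assay compound 4 gives 32.5 nM but compound 2 has no number, so no step can be read between these two compounds. Going by these compounds, what replacing 2,3-dichlorophenyl with 4-bromophenyl does to inhibition stays open, as does where compound 2 and compound 3 stand on the scale. Nothing shown here offers an explanation for the value of compound 4.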